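Moving one methoxy group on a growth-inhibiting amide

The source may hold more compounds than are shown below. What is called first, only, known or untested is meant among the compounds shown, and "the series" means these compounds.

Compound 1 `COc1ccccc1C(=O)Nc1cccc(-c2cc(=O)c3c(OC)c(OC)c(OC)cc3o2)c1` gives 15300 nM
Compound 2 `COc1ccc(C(=O)Nc2cccc(-c3cc(=O)c4c(O)c(OC)c(OC)cc4o3)c2)cc1` gives 2050 nM

In a functional assay on MCF7 cells (Homo sapiens) for inhibition, read by MTT assay (on this read-out higher numbers stand for weaker inhibition of growth and lower numbers for stronger inhibition of growth), compound 2 has the lower of the two numbers, and its gap to compound 1 lies beyond the usual scatter. Compound 3 `COc1ccccc1C(=O)Nc1cccc(-c2cc(=O)c3c(O)c(OC)c(OC)cc3o2)c1` has not yet been measured. It keeps the core of compound 2, but 2-methoxyphenyl stands in place of 4-methoxyphenyl on a carbonyl carbon (2-methoxyphenyl in place of 4-methoxyphenyl on a carbonyl carbon). For the measured compounds named here, no measured pair isolates this change, so its size in this assay is uncertain. Compound 1 also carries 2-methoxyphenyl and gives 15300 nM but its core differs, which makes it only a weak hint toward weaker inhibition. The estimated step is a 1.7-fold higher number from compound 2 to compound 3 (0.23 log units; within the scatter) and is expected to be small, perhaps no larger than the scatter. Compound 3 is expected to give 3500 nM (estimated range 1200 nM to 10000 nM).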

Compound 3, concentration for 50% growth inhibition: 1830 nM
Beside the measured number, compound 3's estimate is 1.9-fold (0.28 log units) above it; measured number inside the range.
By their numbers in this assay, from the lowest: compounds 3 and 2 (each within the scatter of the next); then compound 1.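

In this assay, for the compounds shown here, putting 2-methoxyphenyl in place of 4-methoxyphenyl on a carbonyl carbon gives a 1.1-fold lower number from compound 2 to compound 3 (0.05 log units; within the scatter) and so isolates this change for the first time, showing no difference that can be told from the scatter. The 2-methoxyphenyl group therefore does not by itself go with the high number of compound 1, since hydrogen in place of methyl on an oxygen on an aromatic ring gives an 8.4-fold lower number from compound 1 to compound 3 (0.92 log units; beyond the scatter) with that group kept. No measurement here bears on why either step has the size it has.

Still open, going by these compounds, is how this amide position responds to a group other than methoxyphenyl, such as an aminophenyl or a carboxylic acid. Also open, on these data alone, is what a longer chain, such as ethyl, would do on that oxygen.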